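The compounds below may be only part of what the source reports. "The series", "measured", "known", "first", "only" and "open" are said of these compounds alone.

Values in a functional assay on HL-60 cells (Homo sapiens) for cytotoxicity, read by WST assay, with a stated time of 48 h; a lower number here means a stronger inhibitor, a higher number a weaker inhibitor:
- compound 1 `COc1cc(C(c2ccc(O)c(OC)c2)[C@@H](C)C(C)C)ccc1O`: 20000 nM
- compound 2 `COc1cc(C(c2ccc(O)c(OC)c2)[C@@H](C)[C@H](C)CO)ccc1O`: > 100000 nM (a limit of the assay, not a number)

Compound 2 stands at the limit of > 100000 nM in this assay, at which 1 of the 2 values shown sits. Its position in this assay is therefore known only as a limit.

The next compound is compound 3 `COc1cc(C(c2ccc(O)c(OC)c2)[C@H](C)[C@@H](C)CO)ccc1O`, and the change is the two compounds have the same atoms and bonds and differ only in configuration as drawn: 2 of 2 stereo elements differ (all stereocentres are inverted: mirror images); a stereocentre at a saturated chain carbon is drawn R in compound 2 and S in compound 3; a stereocentre at a saturated chain carbon is drawn S in compound 2 and R in compound 3. Compound 3 is thus the mirror image of compound 2, with no atom or bond gained or lost.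

Among the measured compounds shown here, only one measured step bears on this, and it is indirect: an at least 5.0-fold higher number from compound 1 to compound 2 (0.69 log units; beyond the scatter). That step is the introduction of the hydroxy on the saturated chain, which compound 3 retains. For the measured compounds named here, no measured pair shows what inverting both stereocentres does, so the direction of any change cannot be derived from the data. With the hydroxy retained, compound 3 is expected to remain weak in this assay, with no clear step beyond the scatter, and it may well read only as a limit too.

The expected size of the change is a number no higher from compound 2 to compound 3 (the limit leaves the size open).

For compound 3 the estimate is 100000 nM, with an expected range from 30000 nM to 200000 nM.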

Compound 3, half-maximal inhibitory concentration: > 100000 nM
Compound 3: no number, only a limit; the forecaster's own chance of this, stated with the estimate: 65%; the middle value sits exactly at the limit.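

In this assay compound 3 gives > 100000 nM, a limit of the assay and not a number. Replacing 1,2-dimethylpropyl with 2-(hydroxymethyl)-1-methylpropyl in the other drawn configuration gives an at least 5.0-fold higher number from compound 1 to compound 3 (0.69 log units; beyond the scatter), so the weak reading of the hydroxy-bearing chain is not confined to the configuration of compound 2, and this second step is of the same printed size as an at least 5.0-fold higher number from compound 1 to compound 2 (0.69 log units; beyond the scatter). The step between the two mirror images cannot be read, and any preference for one configuration stays hidden because both compounds sit at the same limit: the limit of > 100000 nM in this assay, at which 2 of the 3 values shown sit.

The compounds shown leave open how far the two mirror images lie past that limit, and so whether configuration at these two stereocentres matters at all in this assay. Also open, on these data alone, is whether an amine or a carboxylic acid in place of the hydroxy, or a longer chain, would read as a number rather than a limit.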